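Methoxy analog of compound 1: expected whole-animal inhibition

This account rests on a few compounds, and the source may have more. Where it says the series, first, only, none or still open, it means among the compounds named here.

Compound 1 `O=C1OC(c2ccc(Cl)cc2)=C/C1=C\c1ccccc1` was tested in a functional assay on the whole organism (strain Wistar) for inhibition, with Rattus norvegicus as the target, with stated times of 30 min and 3 h, at a dose of 20 mg/kg by the oral route (a higher number here means more inhibition at the dose given (going by the name of the read-out), a lower number less inhibition), and compound 1 gives 36%. Compound 2 `O=C1OC(c2ccc(Cl)cc2)=C/C1=C\c1ccc([N+](=O)[O-])cc1` differs from compound 1 by a nitro in place of hydrogen on an aromatic carbon, and in this assay compound 2 gives 36%. The step of no change at the digits printed from compound 1 to compound 2 (within the scatter) is therefore flat, and compound 1 stands level with compound 2 at the digits shown, with no other measured neighbour to place it against.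

Compound 3 `COc1ccc(/C=C2\C=C(c3ccc(Cl)cc3)OC2=O)cc1` is not yet measured. Relative to compound 1 it carries the change (methoxy in place of hydrogen on an aromatic carbon). For the measured compounds named here, the only measured step that bears on this change is the one from compound 1 to compound 2, where a group entered at the same kind of aromatic carbon and no change at the digits printed from compound 1 to compound 2 (within the scatter) showed nothing beyond the scatter. Going by the values given here, with a single flat precedent and no measured step for a methoxy, no shift in this assay beyond the scatter is expected for compound 3, and the expected step is no change at the digits printed from compound 1 to compound 3 (within the scatter). Compound 3 is therefore estimated at 36% in this assay, with a range from 26% to 46%.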

Compound 3, a percentage reported as inhibition, in the whole organism at one dose (the size of the read-out at that dose, not a potency): 32.3%
Estimate against measurement, compound 3: 3.7 percentage points above, and the stated range covers the measured number.
By their numbers in this assay, from the lowest: compounds 3, 1 and 2 (each within the scatter of the next).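

In this assay, methoxy in place of hydrogen on an aromatic carbon, para to a large group, gives a number 3.7 percentage points lower from compound 1 to compound 3 (within the scatter), so this place now has a second substituent to read alongside nitro. The direct exchange of the two groups, methoxy in place of nitro, gives a number 3.7 percentage points lower from compound 2 to compound 3 (within the scatter), which places hydrogen, nitro and methoxy within the scatter of one another across compounds 1, 2 and 3, with none of the three going against this flat picture and no order among them. Nothing available explains why the read-out stays flat across these changes at this place.

From the compounds shown here alone, whether any group at this place can move the read-out beyond the scatter remains open, for example an amine, a carboxylic acid or a longer chain such as butoxy in place of the methoxy of compound 3. The compounds shown also leave open whether the flat picture holds at other doses or at other places on this ring, and what follows from replacing the chlorine on the other aromatic ring of the shared core.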